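A few compounds are considered here, and "the series" means these few. Any claim that something is new, unique, unknown or untested is made for them only; others in the source may bear on it.

Measured compounds and their values:
- compound 1 `Cc1ccc(-c2nnc(SCCCN3CCN(c4cccc(Cl)c4)CC3)[nH]2)cc1` — in a functional assay on THP-1 cells (Homo sapiens) for cytotoxicity, read by MTT assay, with a stated time of 24 h (a lower number here means a stronger inhibitor, a higher number a weaker inhibitor), compound 1 gives > 300000 nM, a limit of the assay.
- compound 2 `CCN1CCN(CCCSc2nnc(-c3ccc(C)cc3)[nH]2)CC1` — compound 2 gives > 300000 nM, again a limit.
- compound 3 `Clc1cccc(-c2nnc(SCCCN3CCN(c4ncccn4)CC3)[nH]2)c1` — compound 3 gives > 300000 nM, also a limit.

Compound 2 therefore stands at the limit rather than at a number, and it shares that position with every other compound here, since (the limit of > 300000 nM in this assay, at which 3 of the 3 values shown sit). Going by the values given here, the single one-place step, a step that the two limits leave unreadable from compound 1 to compound 2, is hidden by the two limits and tells nothing about size or direction.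

Compound 4 `CCN1CCN(CCCSc2nnc(-c3ccccc3Cl)[nH]2)CC1` differs from compound 2 by 2-chlorophenyl in place of 4-methylphenyl on an aromatic carbon. Among the compounds with values here, no measured step touches this change; the only step available is the unreadable one from compound 1 to compound 2, and compound 3 adds nothing beyond a third limit. The expectation for this assay is thus no step beyond the scatter, a number no higher from compound 2 to compound 4 (the limit leaves the size open), and compound 4 is expected to sit again at the limit, estimated at 300000 nM with a range from 100000 nM to 600000 nM.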

Compound 4, half-maximal inhibitory concentration: > 300000 nM
Compound 4: only a limit was reported; the forecaster's own chance of this, stated with the estimate: 85%; the middle value lies on the limit itself.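

In this assay compound 4 gives > 300000 nM, which is a limit. Compound 2 also stands at a limit, so no step between compound 2 and compound 4 can be read: the limit of > 300000 nM in this assay, at which 4 of the 4 values shown sit.

The compounds shown leave open whether 2-chlorophenyl and 4-methylphenyl differ at all in this assay.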